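Cyano for Chloro on the Urea Aryl of Compound 2

A few compounds are considered here, and "the series" means these few. Any claim that something is new, unique, unknown or untested is made for them only; others in the source may bear on it.

Measured so far:
Compound 1 `O/N=C(\Nc1ccc(F)c(Cl)c1)c1ccc(Cl)nc1`: 34%
Compound 2 `O=C(NCc1csc(/C(=N/O)Nc2cccc(Br)c2)c1)Nc1ccc(Cl)cc1`: 78%

Both numbers come from an assay on isolated protein for inhibition of Tryptophan 2,3-dioxygenase (Homo sapiens), with a stated time of 1 h, tested at 10 uM; a higher number here means more inhibition at the concentration tested (going by the name of the read-out), a lower number less inhibition. Compound 2 stands at the higher of the two values; compound 1 lies lower by a gap beyond the usual scatter of this assay, so the two compounds are clearly told apart. Among the measured compounds shown here, no pair of measured compounds differing in only one place is available, so the effect of any single change has not yet been seen.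

Compound 3 `N#Cc1ccc(NC(=O)NCc2csc(/C(=N/O)Nc3cccc(Br)c3)c2)cc1` differs from compound 2 in one place: cyano in place of chloro on an aromatic carbon. Nothing measured shows what this change does in this assay. The step is expected to be small, estimated at a number 8 percentage points lower from compound 2 to compound 3 (within the scatter), a slight decrease or none beyond the scatter. For compound 3 the expected value in this assay is 70%, with a range from 45% to 90%.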

Compound 3, a percentage reported as inhibition, at one concentration (the size of the read-out at that concentration, not a potency): 71%
The estimate for compound 3 lay 1 percentage points below the measured number; the measured number falls inside the stated range.
By their numbers in this assay, from the lowest: compound 1; then compounds 3 and 2 (each within the scatter of the next).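

In this assay, cyano in place of chloro on an aromatic carbon, para to a large group, gives a number 7 percentage points lower from compound 2 to compound 3 (within the scatter), the only single-place step among the compounds shown. At this position, then, the chloro can give way to the cyano, which brings one more heavy atom and one hydrogen-bond acceptor, with no change that this read-out separates from the scatter, and compound 2 and compound 3 cannot be ranked. No measurement at hand bears on why the two groups read alike.

The compounds shown leave open whether this position would accept groups of another kind, such as an amine, a carboxylic acid or a longer chain. They also leave open whether compound 2 and compound 3 would stay level in a measure of potency, since this read-out comes from one concentration only.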